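Chloro on the Core and the Cytotoxicity Limit

The source may report more compounds than this note shows. Statements on the series, on what has been measured and on what is new or still open speak of the compounds shown alone.

Compound 1 `Cc1cc(Oc2ccccc2OCCn2ccc(=O)[nH]c2=O)cc2cc(C#N)ccc12`: 6000 nM
Compound 2 `Cc1cc(Oc2ccccc2OCCn2ccc(=O)[nH]c2=O)c(Cl)c2cc(C#N)ccc12`: only a limit, > 100000 nM
Compound 3 `N#Cc1ccc2ccc(Oc3ccc(F)cc3OCCn3ccc(=O)[nH]c3=O)cc2c1`: only a limit, > 100000 nM

In a toxicity assay on MT2 cells (Homo sapiens) for cytotoxicity, read by MTT assay (a lower number here means that less compound is tolerated, a higher number that more compound is tolerated), compound 1 gives 6000 nM. For compound 2 this assay reports no number but a limit, > 100000 nM. Compound 3 likewise is reported only as a limit, > 100000 nM. The step of an at least 16-fold higher number from compound 1 to compound 2 (1.22 log units; beyond the scatter) follows the change (chloro in place of hydrogen on an aromatic carbon). How the cores of compound 1 and compound 3 differ is not broken down here.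

Compound 4 `N#Cc1ccc2c(Cl)cc(Oc3ccc(F)cc3OCCn3ccc(=O)[nH]c3=O)cc2c1` is not yet measured. It differs from compound 3 by chloro in place of hydrogen on an aromatic carbon, the same kind of change, though the place differs: here it is ortho to a fused ring, meta to a fused ring and meta to a large group, whereas in compound 2 it is ortho to a large group and para to a methyl group. Resting on the step of an at least 16-fold higher number from compound 1 to compound 2 (1.22 log units; beyond the scatter) and on (the limit of > 100000 nM in this assay, at which 2 of the 3 values shown sit), compound 4 is expected to show a step of a number no higher from compound 3 to compound 4 (the limit leaves the size open). Compound 4 is estimated at 100000 nM, with a range from 50000 nM to 300000 nM.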

Compound 4, half-maximal cytotoxic concentration: > 100000 nM
Compound 4: no number, only a limit (the forecaster's own chance of this, stated with the estimate: 85%); the middle value sits exactly at the limit.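

No step can be read from compound 3 to compound 4, because each is reported only as a limit: the limit of > 100000 nM in this assay, at which 3 of the 4 values shown sit.

The compounds shown leave open whether chloro changes the tolerated concentration of compound 3 in this assay at all.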